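Leucine benzyl ester in place of the aspartate diester

A few compounds are considered here, and "the series" means these few. Any claim that something is new, unique, unknown or untested is made for them only; others in the source may bear on it.

Measured compounds:
Compound 1, `C[C@H](NC(=O)CN(c1nc(Cl)nc2[nH]cnc12)C1CC1)C(=O)OCc1ccccc1`, in a functional assay on the whole organism (Tail, strain ICR) with Mus musculus as the target, in the tail flick test, with a stated time of 30 min, at a dose of 25 umol/kg by the oral route (a higher number here means a stronger effect of the compound at the dose given, a lower number a weaker effect), compound 1 gives 41.2%.
Compound 2, `O=C(CN(c1nc(Cl)nc2[nH]cnc12)C1CC1)N[C@@H](CC(=O)OCc1ccccc1)C(=O)OCc1ccccc1`, in this assay compound 2 gives 34.7%.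
Compound 3, `NC(=O)C[C@H](NC(=O)CN(c1ncnc2c1ncn2C1CCCCO1)C1CC1)C(=O)OCc1ccccc1`, in this assay compound 3 gives 34.5%.

Compound 2 stands second of the three numbers in this assay; its nearest neighbour is compound 3, and compound 1 lies furthest from it, both within the scatter. The unmeasured compound 4, `CC(C)C[C@H](NC(=O)CN(c1nc(Cl)nc2[nH]cnc12)C1CC1)C(=O)OCc1ccccc1`, differs from compound 2 in one place: isopropyl in place of benzyloxycarbonyl on a saturated chain carbon, two bonds along the chain from an amide-type nitrogen and a carbonyl carbon.

Among the compounds with values here, only one measured step touches this position. It is a number 6.5 percentage points lower from compound 1 to compound 2 (within the scatter), in which a benzyloxycarbonyl entered onto the same chain carbon without moving the read-out beyond the scatter. The change to compound 4 removes that benzyloxycarbonyl again and puts an isopropyl there instead. Because a number 6.5 percentage points lower from compound 1 to compound 2 (within the scatter) was within the scatter, no step beyond the scatter is expected in this assay; the expected step is a number 4.3 percentage points higher from compound 2 to compound 4 (within the scatter). Compound 4 is therefore estimated at 39%, within a range from 25% to 53%.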

Compound 4, a percentage reported as activity, at one dose (the size of the read-out at that dose, not a potency): 33.9%
For compound 4 the middle estimate is 5.1 percentage points above the measured one; measured number inside the range.
By their numbers in this assay, from the lowest: compounds 4, 3, 2 and 1 (each within the scatter of the next).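

In this assay the isopropyl on the saturated chain carbon gives a number 0.8 percentage points lower from compound 2 to compound 4 (within the scatter), and measured against hydrogen at that carbon it gives a number 7.3 percentage points lower from compound 1 to compound 4 (within the scatter). This position has now carried hydrogen, benzyloxycarbonyl and isopropyl with no step beyond the scatter, so a small group with no ring and no hydrogen-bond acceptors reads the same here as a larger one with an aromatic ring and hydrogen-bond acceptors. Nothing in the data shown offers an explanation for this result.

From the compounds shown here alone, it remains open whether an amine, a carboxylic acid or a longer chain on this carbon would give a step beyond the scatter. Also open, going by these compounds, is whether any of these groups would behave differently on the core of compound 3, which carries no isopropyl or hydrogen at this carbon.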